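Replacing phenoxy with bromo on compound 3

The source may report more compounds than this note shows. Statements on the series, on what has been measured and on what is new or still open speak of the compounds shown alone.

Values in a physicochemical assay for solubility, at pH 7.4; on this read-out higher numbers stand for higher solubility and lower numbers for lower solubility:
- compound 1 `CCOC(=O)c1c(-c2cccc(OCC)c2)[nH]c2cc(OC)ccc2c1=O`: 8700 nM
- compound 2 `CCOC(=O)c1c(-c2cccc(Oc3ccccc3)c2)[nH]c2cc(OC)ccc2c1=O`: 4300 nM
- compound 3 `CCOC(=O)c1c(-c2cccc(Oc3ccccc3)c2)[nH]c2cc(OC)c(F)cc2c1=O`: 4300 nM

Compound 3 stands level with compound 2, and together they hold the lowest of the three numbers, while compound 1 stands apart at 8700 nM. The next compound is compound 4 `CCOC(=O)c1c(-c2cccc(Br)c2)[nH]c2cc(OC)c(F)cc2c1=O`, with bromo in place of phenoxy on an aromatic carbon.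

For the measured compounds named here, two measured steps bear on this change. The closer one is phenyl in place of ethyl on an oxygen on an aromatic ring, which gave a 2.0-fold lower number from compound 1 to compound 2 (0.31 log units; beyond the scatter). It is modest and touches the same substituent. The other is fluoro in place of hydrogen on an aromatic carbon, which gave no change at the digits printed from compound 2 to compound 3 (within the scatter), so the fluoro carried by compound 3 calls for no correction. Going by the values given here, no measured compound carries bromo, so its contribution in this assay is unknown and the range has to stay wide.

With phenoxy leaving, a modest move towards higher numbers is expected, resting on a 2.0-fold lower number from compound 1 to compound 2 (0.31 log units; beyond the scatter) taken in reverse. The expected change is a 1.5-fold higher number from compound 3 to compound 4 (0.18 log units; within the scatter). For compound 4 the estimated value is 6500 nM, with an expected range of 3000 nM to 14000 nM.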

Compound 4, solubility: 7300 nM
For compound 4 the middle estimate is 1.1-fold (0.05 log units) below the measured one, within the range that was stated.
By their numbers in this assay, from the lowest: compounds 2, 3, 4 and 1 (each within the scatter of the next, the first and the last beyond it).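

In this assay, for the compounds shown here, the exchange of phenoxy for bromo gives a 1.7-fold higher number from compound 3 to compound 4 (0.23 log units; within the scatter) and is the first change to remove the whole group on this aromatic carbon, rather than only the part attached through the oxygen. The seven heavy atoms of phenoxy, with its aromatic ring and its hydrogen-bond acceptor, therefore give way to a single bromine without a step beyond the scatter, whereas the earlier change of substituent on that oxygen, a 2.0-fold lower number from compound 1 to compound 2 (0.31 log units; beyond the scatter), was printed as beyond it. On these numbers, the ring of phenoxy cannot be separated from bromo at this place, and nothing available explains the reading.

Still open is whether an amine or a carboxylic acid on this aromatic carbon would move the number beyond the scatter, as neither group appears among these compounds. Also open, going by these compounds, is whether bromo would give a similar step on the core of compound 2, which lacks the fluoro carried by compound 3 and compound 4.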